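The compounds below may be only part of what the source reports. "The series", "measured", "known", "first", "only" and "open" are said of these compounds alone.

Compound 2 `CCCCc1[nH]c(=O)c(S(=O)(=O)c2ccc(-c3ccc(F)nc3)cc2)c(O)c1-c1c(OC)cccc1OC` carries a 6-fluoropyridin-3-yl group on the phenyl ring that bears the sulfonyl linker, and in an ADME assay for permeability, using PAMPA, at pH 7.4 (on this read-out lower numbers stand for lower permeability and higher numbers for higher permeability), the result for compound 2 is "not determined" (no result reported). Compound 2 thus has no reported result in this assay, so its standing there cannot be placed on any number. Among the compounds with values here, the only measured reference is compound 1 `CCCCc1nc(=O)c(S(=O)(=O)c2ccc(-c3cccnc3)cc2)c(O)n1-c1c(OC)cccc1OC`, whose core differs from that of compound 2; in this assay compound 1 gives 6 nm/s, a low reading.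

Compound 3 `CCCCc1[nH]c(=O)c(S(=O)(=O)c2ccc(-n3cc(Cl)ccc3=O)cc2)c(O)c1-c1c(OC)cccc1OC` differs from compound 2 by a group of 8 heavy atoms (5 carbon, 1 nitrogen, 1 oxygen, 1 chlorine; one six-membered aromatic ring with 1 hetero atom) in place of a group of 7 heavy atoms (5 carbon, 1 nitrogen, 1 fluorine; one six-membered aromatic ring with 1 hetero atom), on an aromatic carbon. Within the data shown here, no step between measured compounds with this change has been recorded, so its size cannot be read from the data at hand. With compound 2 unmeasured and compound 1 the only anchor, the expectation for compound 3 in this assay is a reading that stays low, near the value of compound 1 6 nm/s, and any shift from compound 2 may well sit within the scatter or fall slightly toward lower permeability. Compound 3 is therefore estimated at 4 nm/s in this assay, with a range from 1 nm/s to 15 nm/s.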

Compound 3, apparent permeability: 22 nm/s
The estimate for compound 3 lay 5.5-fold (0.74 log units) below the measured number, outside the stated range (above it).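

In this assay compound 3 gives 22 nm/s but compound 2 has no reported number to set against it, so no step can be read from compound 2 to compound 3. The compounds shown leave open what swapping the 6-fluoropyridin-3-yl group for the group in compound 3 does to this read-out on the shared core. Nothing at hand offers an explanation for the result.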